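Thiophene Out, Acetylphenyl In: What to Expect

A few compounds are considered here, and "the series" means these few. Any claim that something is new, unique, unknown or untested is made for them only; others in the source may bear on it.

Measured so far:
compound 1, `COc1ccc(-c2cn3ccnc3c(-c3ccc4ncn(C5CCCCC5)c4c3)n2)cc1`: 82.8%
compound 2, `c1cn2cc(-c3ccsc3)nc(-c3ccc4ncn(C5CCCCC5)c4c3)c2n1`: 30%

Both compounds were tested in a functional assay on MOLT-4 cells (Homo sapiens) for inhibition, read by sulforhodamine B assay, with a stated time of 48 h, tested at 10 uM; on this read-out lower numbers stand for less inhibition and higher numbers for more inhibition at the one concentration tested (going by the name of the read-out). Among the compounds with values here, compound 1 gives 82.8% and compound 2 gives 30%, so compound 2 stands lowest of the two numbers, with compound 1 as its only neighbour. Within the data shown here, the single measured step, a number 52.8 percentage points lower from compound 1 to compound 2 (beyond the scatter), came with thiophen-3-yl in place of 4-methoxyphenyl on an aromatic carbon.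

Compound 3, `CC(=O)c1ccc(-c2cn3ccnc3c(-c3ccc4ncn(C5CCCCC5)c4c3)n2)cc1`, has not yet been measured. It differs from compound 2 thus: 4-acetylphenyl in place of thiophen-3-yl on an aromatic carbon. This change puts a six-membered carbon ring back where compound 1 also carried one, so the step from compound 1 to compound 2 is the one that bears on it, and it was large. Compound 3 is therefore expected to climb, the estimated step being a number 40 percentage points higher from compound 2 to compound 3 (beyond the scatter). The estimate for compound 3 is 70%, with a range from 40% to 90%.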

Compound 3, a percentage reported as inhibition, at one concentration (the size of the read-out at that concentration, not a potency): 14.3%
For compound 3 the middle estimate is 55.7 percentage points above the measured one; measured number outside the range, below it.
By their numbers in this assay, from the lowest: compound 3; then compound 2; then compound 1.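

In this assay, putting a six-membered carbon ring at this position does not by itself restore the higher number: 4-acetylphenyl in place of thiophen-3-yl gives a number 15.7 percentage points lower from compound 2 to compound 3 (beyond the scatter) and so moves the value further away from that of compound 1. Within the data shown here, what the ring carries matters greatly, as acetyl in place of methoxy, with everything else unchanged, gives a number 68.5 percentage points lower from compound 1 to compound 3 (beyond the scatter) and is the only change separating these two compounds. Nothing measured here explains why either step occurs.

On these data alone, it remains open whether a plain phenyl ring with no added group would read closer to compound 1 or to compound 3. As far as these compounds go, how an amine, a carboxylic acid or a longer ether chain on the same ring would read also remains unknown.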